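Ethoxycarbonyl in place of carboxy on compound 1

The source may report more compounds than this note shows. Statements on the series, on what has been measured and on what is new or still open speak of the compounds shown alone.

Measured in a functional assay (Mus musculus) for inhibition, with a stated time of 5 days (a higher number here means a weaker inhibitor, a lower number a stronger inhibitor), so far
- compound 1 `O=C(O)/C=C/c1cn(-c2ccc(O)cc2)nc1-c1cc(O)ccc1O` gives > 100000 nM as a limit
- compound 2 `O=C(O)/C=C/c1cn(-c2ccc(O)cc2)nc1-c1ccccc1` gives > 100000 nM as a limit

Compound 1 at > 100000 nM in this assay is a limit and not a number. Compound 2 at > 100000 nM is likewise a limit. Among the measured compounds shown here, both measured compounds share the limit of > 100000 nM in this assay, at which 2 of the 2 values shown sit, and the series so far holds no readable number.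

Compound 3 `CCOC(=O)/C=C/c1cn(-c2ccc(O)cc2)nc1-c1cc(O)ccc1O` carries ethyl in place of hydrogen on an oxygen next to a carbonyl group and so reads carboxy to ethoxycarbonyl. For the measured compounds named here, the one measured step is a step that the two limits leave unreadable from compound 1 to compound 2 and lies at another place, on an aromatic carbon, so it offers no size to carry over.

With compound 1 at > 100000 nM as its limit, any expected move in this assay runs towards stronger inhibition, and a second limit is about as likely as a number. The expected outcome is an at least 2.5-fold lower number from compound 1 to compound 3 (0.39 log units; beyond the scatter) as a rough estimate with no measured size behind it. For compound 3 the estimate is 40000 nM with an expected range from 10000 nM to 100000 nM as working bounds.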

Compound 3, half-maximal inhibitory concentration: 12000 nM
Compound 3: the middle estimate sits 3.3-fold (0.52 log units) above what was measured, within the range that was stated.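

In this assay, ethyl in place of hydrogen on an oxygen next to a carbonyl group gives an at least 8.3-fold lower number from compound 1 to compound 3 (0.92 log units; beyond the scatter). Compound 1 gives > 100000 nM, which is a limit and not a number, so the size of this step is only a bound and the true difference may be larger. This position is the only place shown where a change leads from a limit to a readable number, and compound 3 now provides the sole value in the series against which later changes can be sized: the limit of > 100000 nM in this assay, at which 2 of the 3 values shown sit.

Going by these compounds, the step with phenyl in place of 2,5-dihydroxyphenyl lies between two limits and cannot be read, so the contribution of the 2,5-dihydroxyphenyl group remains unknown, as does whether ethoxycarbonyl would give a readable number alongside phenyl. Also open, on these data alone, is whether the gain is specific to ethyl or would extend to a methyl group or a longer chain on the same oxygen, and how an amide in place of ethoxycarbonyl would read in this assay.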